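The source may hold more compounds than are shown below. What is called first, only, known or untested is meant among the compounds shown, and "the series" means these compounds.

Measured so far in a functional assay (Oryctolagus cuniculus) for inhibition; a higher number here means a weaker inhibitor, a lower number a stronger inhibitor:
compound 1 `O=c1ccn(COCCO)c(=O)[nH]1`: > 400 ug/mL
compound 2 `Nc1ccn(COCCO)c(=O)n1`: > 400 ug/mL
compound 3 `Nc1nc(=O)ccn1COCCO`: > 400 ug/mL

In this assay compound 1 gives only a limit of the assay, > 400 ug/mL, and no number. Compound 2 likewise gives only a limit, > 400 ug/mL. Compound 3 also stops at a limit, > 400 ug/mL. Compound 1 therefore stands nowhere distinct on the numbers shown: all three measured compounds sit at the limit of > 400 ug/mL in this assay, at which 3 of the 3 values shown sit, so no step between measured compounds can be sized and no ordering among compounds 1, 2 and 3 is possible.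

Compound 4 `O=c1[nH]c(=O)n(COCCO)cc1/C=C/Br` is still to be measured in this assay. It differs from compound 1 in one place: 2-bromoethenyl in place of hydrogen on an aromatic carbon. The measured set carries nothing comparable, since compounds 1, 2 and 3 vary only the core and all remain at the limit. Compound 4 is expected to give 150 ug/mL, with a range from 30 ug/mL to 400 ug/mL. The expected step of an at least 2.6-fold lower number from compound 1 to compound 4 (0.42 log units; beyond the scatter) is in the direction of stronger inhibition but of uncertain size, and a result that again stops at the limit is about as likely as a number.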

Compound 4, concentration for 50% inhibition: > 400 ug/mL
Compound 4: a limit, no number (the forecaster's own chance of this, stated with the estimate: 55%); at least 2.6-fold (0.42 log units) between middle value and limit.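

In this assay compound 4 gives only a limit of the assay, > 400 ug/mL. Compound 1 also stops at a limit, so no step can be read between compound 1 and compound 4: the limit of > 400 ug/mL in this assay, at which 4 of the 4 values shown sit.

The compounds shown leave open whether 2-bromoethenyl in place of hydrogen on an aromatic carbon changes inhibition at all.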